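The source may report more compounds than this note shows. Statements on the series, on what has been measured and on what is new or still open speak of the compounds shown alone.

Three compounds share a core and are compared in a functional assay (aorta) with Oryctolagus cuniculus as the target; on this read-out higher numbers stand for weaker inhibition and lower numbers for stronger inhibition. Compound 1, `OCc1ccc(-c2nn(Cc3ccccc3F)c3cccnc23)o1`, gives 20400 nM in this assay. Compound 2, `Cc1nc(-c2nn(Cc3ccccc3F)c3ncccc23)oc1CO`, gives 900 nM in this assay. Compound 3, `CC(C)c1cnc(-c2nn(Cc3ccccc3F)c3ncccc23)nc1N`, gives 207000 nM in this assay, the highest of the three numbers: compound 1 sits a step below it that lies beyond the scatter, and compound 2 sits much further below, also beyond the scatter. Compound 3 is therefore the weakest inhibitor among the measured compounds.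

The unmeasured compound 4, `Nc1nc(-c2nn(Cc3ccccc3F)c3ncccc23)ncc1CC(F)(F)F`, differs from compound 3 in one place: 2,2,2-trifluoroethyl in place of isopropyl on an aromatic carbon. Among the compounds with values here, the group that leaves and the group that enters are of similar size, neither carries a hydrogen-bond donor or acceptor, and no measured pair in this set shows what such an exchange does in this assay. Within the data shown here, there is thus no measured step to lean on, and the expectation can only be a modest one. Compound 4 is expected to stay close to compound 3, with a step of a 1.4-fold lower number from compound 3 to compound 4 (0.14 log units; within the scatter) that may well fall within the scatter. The estimated value for compound 4 in this assay is 150000 nM, with a range from 40000 nM to 600000 nM.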

Compound 4, half-maximal inhibitory concentration: 508000 nM
For compound 4 the middle estimate is 3.4-fold (0.53 log units) below the measured one; the range from low to high includes it.
By their numbers in this assay, from the lowest: compound 2; then compound 1; then compound 3; then compound 4.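

Within the data shown here, this is the first measured exchange at this position, on the aromatic carbon ortho to the amino group, and in this assay it gives a 2.5-fold higher number from compound 3 to compound 4 (0.39 log units; beyond the scatter). The step is modest, but it lies beyond the usual scatter, and since a higher number here means weaker inhibition, the position is not indifferent to the exchange, even though neither isopropyl nor 2,2,2-trifluoroethyl carries a hydrogen-bond donor or acceptor. Nothing in the data explains why the number rises, so the reason for the step remains unknown.

Going by these compounds, what the position does with other kinds of group remains open: a carboxylic acid, an amine or a longer chain such as n-butyl could each move the number up or down, and a bare hydrogen at this carbon would show what the isopropyl and 2,2,2-trifluoroethyl groups each contribute in the first place. A single pair also cannot show whether the same exchange would have a step of similar size and direction on a different core.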